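This account rests on a few compounds, and the source may have more. Where it says the series, first, only, none or still open, it means among the compounds named here.

Compound 1, `c1ccc(N2CCCCC2)c(NCC2=NCCN2)c1`, gives 114% in a functional assay for activation of Alpha-1A adrenergic receptor (Homo sapiens); a lower number here means a smaller maximal response, a higher number a larger maximal response.
Compound 2, `c1ccc(N2CCCCC2)c(NCc2c[nH]cn2)c1`, gives 95%.
Compound 3, `Oc1ccc2cccc(NCC3=NCCN3)c2c1`, gives 110%.

The one counted step among these three is a number 19 percentage points lower from compound 1 to compound 2 (beyond the scatter), which goes with the change (a group of 5 heavy atoms (3 carbon, 2 nitrogen; one five-membered aromatic ring with 2 hetero atoms) in place of a group of 5 heavy atoms (3 carbon, 2 nitrogen; one five-membered non-aromatic ring with 2 hetero atoms), on a saturated chain carbon bound to a nitrogen on an aromatic ring). Compound 3 and compound 1 lie within the scatter of each other, while compound 3 stands beyond the scatter from compound 2. How the core of compound 3 differs from the core of compound 1 is not broken down here.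

Compound 4, `Oc1ccc2cccc(NCc3c[nH]cn3)c2c1`, is still to be measured in this assay. For the measured compounds named here, it differs from compound 3 by a group of 5 heavy atoms (3 carbon, 2 nitrogen; one five-membered aromatic ring with 2 hetero atoms) in place of a group of 5 heavy atoms (3 carbon, 2 nitrogen; one five-membered non-aromatic ring with 2 hetero atoms), on a saturated chain carbon bound to a nitrogen on an aromatic ring, the same change as the one made from compound 1 to compound 2. A step of similar size is therefore expected, a number 18 percentage points lower from compound 3 to compound 4 (beyond the scatter), because the same change gave a number 19 percentage points lower from compound 1 to compound 2 (beyond the scatter). Compound 4 is thus estimated at 92%, with a range from 76% to 108%.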

Compound 4, largest response reached (reported as maximum), in percent of the reference or control that the assay uses: 100%
The estimate for compound 4 lay 8 percentage points below the measured number; the range from low to high includes it.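

Carrying the swap from the five-membered non-aromatic ring to 1H-imidazol-4-yl onto the core of compound 3 gave a number 10 percentage points lower from compound 3 to compound 4 (within the scatter) in this assay. Set beside the earlier step, the two do not differ: the same change on two cores in this assay, a number 19 percentage points lower (beyond the scatter) from compound 1 to compound 2 and a number 10 percentage points lower (within the scatter) from compound 3 to compound 4, 9 percentage points apart, within the scatter of two such steps. For the compounds shown here, the change thus carries from one core to the other with no detectable difference in step size, but this rests on only two pairs, and since only the first step stands beyond the scatter, it does not show that the swap lowers the maximal response on every core.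

The compounds shown leave open how the swap behaves on further cores. They also leave open whether a simple amine or a carboxylic acid in place of either ring, or a longer chain carrying it, would keep the maximal response.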